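Replacing a Benzamide with a Pyridinylmethyl Carbamate

This account rests on a few compounds, and the source may have more. Where it says the series, first, only, none or still open, it means among the compounds named here.

Compound 1, `Cc1cc(C(N)=O)nn1Cc1cc(Cl)ccc1OCc1ccccc1`, carries a carbamoyl group on the shared core. In a physicochemical assay for lipophilicity, at pH 7.4 (a lower number here means a more polar compound, a higher number a more lipophilic compound), compound 1 gives 3.7. Compound 2, `Cc1cc(NC(=O)c2ccccc2)nn1Cc1cc(Cl)ccc1OCc1ccccc1`, carries a benzamido group in its place. In this assay compound 2 gives only a limit, > 3.7, not a number. The step of a number no lower from compound 1 to compound 2 (the limit leaves the size open) therefore has no readable size; what is known is that compound 2 sits at the limit of > 3.7 in this assay, at which 1 of the 2 values shown sits.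

Compound 3, `Cc1cc(NC(=O)OCc2ccccn2)nn1Cc1cc(Cl)ccc1OCc1ccccc1`, differs from compound 2 in one place: (pyridin-2-yl)methoxy in place of phenyl on a carbonyl carbon. Within the data shown here, no measured step touches this carbonyl carbon, so the step from compound 1 to compound 2, which concerns a different position, does not bear directly on it. The expectation for compound 3 therefore rests on the counted difference alone, namely the nitrogen and oxygen that enter where a carbon-only ring leaves. The step of a number at least 0.20 log units lower from compound 2 to compound 3 (that floor lies within the scatter) is expected to be a decrease. Compound 3 is estimated at 3.5, with a range from 2.8 to 4.2.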

Compound 3, distribution coefficient: 3.1
Compound 3: middle estimate off by 0.40 log units, on the high side; the measured number falls inside the stated range.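

In this assay, among these compounds, (pyridin-2-yl)methoxy in place of phenyl on the carbonyl carbon gives a number at least 0.60 log units lower from compound 2 to compound 3 (beyond the scatter), the first step at this position with a direction that clears the scatter. From the compounds shown here alone, that step can be stated only as a floor, and its true size stays unknown, because compound 2 is known only through a limit: the limit of > 3.7 in this assay, at which 1 of the 3 values shown sits. Measured against the carbamoyl compound, the (((pyridin-2-yl)methoxy)carbonyl)amino group gives a number 0.60 log units lower from compound 1 to compound 3 (beyond the scatter), which shows that a replacement for carbamoyl on this aromatic carbon can read lower in this assay and gives the series its first pair of exact numbers for such a replacement.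

The nitrogen and the oxygen enter together in this change, so the compounds shown do not tell how much of the step belongs to the pyridine ring and how much to the oxygen-containing link. Going by these compounds, how a benzyloxy group, which would keep the link but restore the carbon-only ring, or a pyridin-2-yl group, which would keep the ring without the link, would read on this carbonyl carbon also remains open.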